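Epimer of the oxazolidinedione at the ring stereocentre

The compounds below may be only part of what the source reports. "The series", "measured", "known", "first", "only" and "open" are said of these compounds alone.

Measured so far:
compound 1 `CC(C)[C@@H](c1ccc(-c2ccc3cccc(F)c3c2)[nH]c1=O)[C@@H]1OC(=O)NC1=O`: 27400 nM
compound 2 `CC(C)[C@H](C[C@H]1OC(=O)NC1=O)c1ccc(-c2ccc3cccc(F)c3c2)[nH]c1=O`: 35400 nM

In a physicochemical assay for solubility, in phosphate buffer, measured as kinetic solubility (on this read-out lower numbers stand for lower solubility and higher numbers for higher solubility), compound 1 gives 27400 nM and compound 2 gives 35400 nM. Within the data shown here, the two values sit within the scatter of each other, and the only measured step, a 1.3-fold higher number from compound 1 to compound 2 (0.11 log units; within the scatter), is a change in where the ring is attached rather than in configuration.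

Compound 3 `CC(C)[C@H](C[C@@H]1OC(=O)NC1=O)c1ccc(-c2ccc3cccc(F)c3c2)[nH]c1=O` is not yet measured. It differs from compound 2 as follows: the two compounds have the same atoms and bonds and differ only in configuration as drawn: 1 of 2 stereo elements differ; a stereocentre at a saturated ring carbon is drawn R in compound 2 and S in compound 3. Among the measured compounds shown here, no measured step in this assay changes configuration alone, so there is nothing here to show that inverting this stereocentre moves the solubility in either direction. The expectation is therefore a step of a 1.0-fold lower number from compound 2 to compound 3 (0.00 log units; within the scatter), within the scatter, against compound 2. Compound 3 is estimated at 35000 nM, with a range from 17000 nM to 70000 nM.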

Compound 3, solubility: 21100 nM
Compound 3: the middle estimate sits 1.7-fold (0.22 log units) above what was measured, within the range that was stated.
By their numbers in this assay, from the lowest: compounds 3, 1 and 2 (each within the scatter of the next).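

In this assay, among these compounds, a 1.7-fold lower number from compound 2 to compound 3 (0.22 log units; within the scatter) is the first reading of configuration alone at this saturated ring carbon, and the R and S drawings are not separated. The exchange of (2,4-dioxo-1,3-oxazolidin-5-yl)methyl for 2,4-dioxo-1,3-oxazolidin-5-yl now has a second reading, a 1.3-fold lower number from compound 1 to compound 3 (0.11 log units; within the scatter), so neither the change of attachment nor the inversion has yet given a step beyond the scatter in this series. The first of these steps can be read as a pure stereo comparison, with no other structural change to allow for: the fact that compounds 2 and 3 differ only in the configuration as drawn

Still open, on these data alone, is whether a carboxylic acid or an amine in place of the 2,4-dioxo-1,3-oxazolidin-5-yl ring would give a step beyond the scatter in this assay. Also open, as far as these compounds go, is whether inverting the other stereocentre, the chain carbon, would do so.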